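The source may report more compounds than this note shows. Statements on the series, on what has been measured and on what is new or still open speak of the compounds shown alone.

Compound 1: `O=C(Nc1ccccc1)c1ccc(-c2ncccc2C(F)(F)F)cc1` — > 4000 nM
Compound 2: `CC(C)(C)c1ccc(NC(=O)c2ccc(-c3ncccc3C#N)cc2)cc1` — 30 nM

In a functional assay for antagonist activity at transient receptor potential cation channel subfamily V member 1 (Homo sapiens), read by FLIPR (on this read-out lower numbers stand for stronger inhibition and higher numbers for weaker inhibition), compound 1 gives only a limit of the assay, > 4000 nM. That value is the limit of > 4000 nM in this assay, at which 1 of the 2 values shown sits. Compound 2 gives 30 nM in this assay, and it holds the only number shown. Compound 3, `CC(C)(C)c1ccc(NC(=O)c2ccc(-c3ncccc3N(S(C)(=O)=O)S(C)(=O)=O)cc2)cc1`, has not yet been measured in this assay. It differs from compound 2 in a single place: bis(methylsulfonyl)amino in place of cyano on an aromatic carbon. Within the data shown here, no two measured compounds differ in only one place, so there is no measured step of this kind to lean on, and the gap between compound 1 and compound 2 tells only that a group at this place matters. The expected step is a 13-fold higher number from compound 2 to compound 3 (1.12 log units; beyond the scatter), toward weaker inhibition and beyond the usual scatter, with a real chance that only a limit is reported. Compound 3 is estimated at 400 nM, within a range from 40 nM to 4000 nM.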

Compound 3, half-maximal inhibitory concentration: 0.8 nM
Compound 3: middle estimate off by 500-fold (2.70 log units), on the high side; measured number outside the range, below it.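

In this assay, the step from cyano to bis(methylsulfonyl)amino gives a 38-fold lower number from compound 2 to compound 3 (1.57 log units; beyond the scatter), so inhibition gets much stronger. Among these compounds, the earlier compounds suggested only that a group at this place matters, whereas this single change shows the direction of its effect on a shared core. The place, on an aromatic carbon two atoms from the ring nitrogen, accepts a group of 9 heavy atoms in place of one of 2 heavy atoms, and the gain comes with no hydrogen-bond donor entering.

On these data alone, how a plain amine, or an amine carrying just one methylsulfonyl group, would compare at this place stays open, so it is unclear whether the whole group is needed. Nothing measured here accounts for the gain.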